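Benzyl for tert-Butyl on a Cell Viability Read-out

The source may hold more compounds than are shown below. What is called first, only, known or untested is meant among the compounds shown, and "the series" means these compounds.

Compound 1 `CC(C)(CO)[C@H](O)C(=O)N/C=C/C(=O)OCc1ccccc1`: 19%
Compound 2 `CC(C)(C)OC(=O)/C=C\NC(=O)[C@H](O)C(C)(C)CO`: -14%
Compound 3 `CC(C)(C)OC(=O)/C=C/NC(=O)[C@@H](O)C(C)(C)CO`: 14%

These three compounds were tested in an ADME assay on WI-38 cells (Homo sapiens) for inhibition, read by CellTiter-Glo, with a stated time of 48 h, tested at 100 uM; on this read-out lower numbers stand for less inhibition and higher numbers for more inhibition at the one concentration tested (going by the name of the read-out). Compound 3 and compound 1 are separated by one change, (benzyl in place of tert-butyl on an oxygen next to a carbonyl group), and the step is a number 5 percentage points higher from compound 3 to compound 1 (within the scatter). Compound 2 and compound 3 are separated by the two compounds have the same atoms and bonds and differ only in configuration as drawn: 2 of 2 stereo elements differ; a stereocentre at a saturated chain carbon is drawn S in compound 3 and R in compound 2; a double bond is drawn E in compound 3 and Z in compound 2; here the step is a number 28 percentage points higher from compound 2 to compound 3 (beyond the scatter), and the only thing that separates them is the fact that compounds 2 and 3 differ only in the configuration as drawn. Compound 2 stands lowest of the three.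

Compound 4 `CC(C)(CO)[C@@H](O)C(=O)N/C=C\C(=O)OCc1ccccc1` has not yet been measured. It differs from compound 2 by benzyl in place of tert-butyl on an oxygen next to a carbonyl group, the same change already seen from compound 3 to compound 1. In this assay the expected step is a number 5 percentage points higher from compound 2 to compound 4 (within the scatter), resting on the measured step of a number 5 percentage points higher from compound 3 to compound 1 (within the scatter). Compound 4 is therefore estimated at -9%, with a range from -30% to 14%.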

Compound 4, a percentage reported as inhibition, at one concentration (the size of the read-out at that concentration, not a potency): 4%
Estimate against measurement, compound 4: 13 percentage points below; measured number inside the range.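

In this assay, benzyl in place of tert-butyl now reads a number 18 percentage points higher from compound 2 to compound 4 (beyond the scatter), and beside the earlier step the two do not differ: the same change on two cores in this assay, a number 5 percentage points higher (within the scatter) from compound 3 to compound 1 and a number 18 percentage points higher (beyond the scatter) from compound 2 to compound 4, 13 percentage points apart, within the scatter of two such steps. This shows the change carrying across these two cores without a gap beyond the scatter, but it does not fix a size for the change, as one step lies within the scatter and the other beyond it. The remaining new step, a number 15 percentage points lower from compound 1 to compound 4 (beyond the scatter), changes the stereocentre and the double bond together, so it cannot assign the shift to either one: the fact that compounds 1 and 4 differ only in the configuration as drawn.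

The compounds shown leave open whether a stereocentre or double bond change alone would shift the number. They also leave open how a free carboxylic acid or a longer chain on the ester oxygen would read.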